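The source may hold more compounds than are shown below. What is called first, only, known or untested is meant among the compounds shown, and "the series" means these compounds.

Measured so far:
- compound 1, `COc1ccc(C(=O)/C=C/c2ccc(Br)cc2)c2c1C=CC(C)(C)O2`: > 10000 nM
- compound 2, `COc1ccc(C(=O)/C=C/c2ccc3ccccc3n2)c2c1C=CC(C)(C)O2`: 3020 nM

Both values come from a functional assay on K562 cells (Homo sapiens) for antiproliferative activity, read by MTT assay, with a stated time of 24 h; a lower number here means a stronger inhibitor, a higher number a weaker inhibitor. Compound 1 gives > 10000 nM, which is a limit of the assay and not a number. Compound 1 thus sits at the limit of > 10000 nM in this assay, at which 1 of the 2 values shown sits. Compound 2, with its different ring on the same side of the chain, gives 3020 nM, an actual number.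

Compound 3 `COc1ccc(C(=O)/C=C/c2cccc(O)c2)c2c1C=CC(C)(C)O2` has not yet been tested. It differs from compound 1 in a single place: 3-hydroxyphenyl in place of 4-bromophenyl on a double-bonded chain carbon bound to a double-bonded chain carbon. Among the compounds with values here, no measured pair shows this particular exchange, so the size of the step it brings in this assay cannot be read from the data; it can only be expected. Because compound 1 stands at the limit of > 10000 nM in this assay, at which 1 of the 2 values shown sits, any real number obtained for compound 3 would already mark a move toward a stronger inhibitor, yet there is no reason from the numbers shown to expect a large one. Compound 3 is expected to give about 10000 nM, within a range from 2500 nM to 40000 nM. That estimate means an expected step of a number no higher from compound 1 to compound 3 (the limit leaves the size open), small and uncertain in direction.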

Compound 3, half-maximal inhibitory concentration: > 10000 nM
Compound 3: no number, only a limit; the forecaster's own chance of this, stated with the estimate: 50%; the middle value lies on the limit itself.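

Within the data shown here, compound 1 and compound 3 both stand at a limit and not at a number, so no step between them can be read in this assay. The compounds shown leave open how strong either compound really is, and so whether 3-hydroxyphenyl in place of 4-bromophenyl changes anything in this assay.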